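Chloromethylbenzyl chloropurines: loss of one chloro

The source may report more compounds than this note shows. Statements on the series, on what has been measured and on what is new or still open speak of the compounds shown alone.

Measured so far:
compound 1 `ClCc1ccc(Cn2cnc3c(Cl)ncnc32)cc1`: 9330 nM
compound 2 `ClCc1ccccc1Cn1cnc2c(Cl)nc(Cl)nc21`: "not determined" (no result reported)

Going by the values given here, compound 2 has no number in a functional assay on SF-268 cells (Homo sapiens) for cytotoxicity, read by sulforhodamine B assay, with a stated time of 48 h; a lower number here means that less compound is tolerated, a higher number that more compound is tolerated; the only measured value in this assay is that of compound 1, which gives 9330 nM. Compound 3 `ClCc1ccccc1Cn1cnc2c(Cl)ncnc21` is obtained from compound 2 by hydrogen in place of chloro on an aromatic carbon, in words: hydrogen in place of chloro on an aromatic carbon. Among the compounds with values here, no step between measured compounds is available to size this change; with compound 1 as the sole reference, no shift beyond the scatter of this assay is expected. Compound 3 is therefore estimated at 10000 nM, within 3000 nM to 35000 nM.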

Compound 3, concentration lethal to 50% of the cells: > 100000 nM
Compound 3: only a limit was reported; the forecaster's own chance of this, stated with the estimate: 15%; middle value at least 10-fold (1.00 log units) from the limit.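

In this assay compound 3 gives > 100000 nM, a limit and not a number. Going by these compounds alone, with compound 2 also lacking a number, no step between compound 2 and compound 3 can be read. Going by these compounds, the size of any shift from hydrogen in place of chloro remains open.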